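A few compounds are considered here, and "the series" means these few. Any claim that something is new, unique, unknown or untested is made for them only; others in the source may bear on it.

Compound 1 `CS(=O)(=O)c1ccc(-c2cnc3[nH]cc(-c4nnc(-c5ccncc5)o4)c(=O)c3c2)cc1` has been tested in a functional assay on HepG2 cells (Homo sapiens) for inhibition, read by MTT assay, with a stated time of 24 h, tested at 5 uM (on this read-out lower numbers stand for less inhibition of growth and higher numbers for more inhibition of growth at the one concentration tested), where compound 1 gives 3.49%. This is the smallest of the three numbers measured, although compound 3 `CS(=O)(=O)c1ccc(-c2cnc3[nH]cc(-c4nnc(-c5ccccc5)o4)c(=O)c3c2)cc1` with 5.46% and compound 2 `CS(=O)(=O)c1ccc(-c2cnc3[nH]cc(-c4nnc(-c5ccc(F)cc5)o4)c(=O)c3c2)cc1` with 9.45% both lie within the scatter of it. Compound 4 `Cc1ccc(-c2nnc(-c3c[nH]c4ncc(-c5ccc(S(C)(=O)=O)cc5)cc4c3=O)o2)cc1` has not yet been measured. It differs from compound 1 in one place: 4-methylphenyl in place of pyridin-4-yl on an aromatic carbon. Going by the values given here, two measured steps bear on this change, since each also replaces pyridin-4-yl on an aromatic carbon: a number 6 percentage points higher from compound 1 to compound 2 (within the scatter) and a number 2 percentage points higher from compound 1 to compound 3 (within the scatter). Neither moved the number beyond the scatter, so no step beyond the scatter is expected in this assay for compound 4 either. The estimate for compound 4 is 6%, between -4% and 16%, which means an expected a number 2.5 percentage points higher from compound 1 to compound 4 (within the scatter).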

Compound 4, percent growth inhibition at one concentration: 6.9%
The estimate for compound 4 lay 0.9 percentage points below the measured number, within the range that was stated.
By their numbers in this assay, from the lowest: compounds 1, 3, 4 and 2 (each within the scatter of the next).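

In this assay, 4-methylphenyl in place of pyridin-4-yl gives a number 3.4 percentage points higher from compound 1 to compound 4 (within the scatter), so a third carbon-only ring on this carbon also stays within the scatter. On that ring, methyl in place of hydrogen gives a number 1.4 percentage points higher from compound 3 to compound 4 (within the scatter), and methyl in place of fluoro gives a number 2.6 percentage points lower from compound 2 to compound 4 (within the scatter), so neither change separates these compounds. No evidence here explains these results. On these data alone, all four groups at this position are six-membered aromatic rings, so the effect of an amine, a carboxylic acid or a longer chain remains open.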